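Trimming the sulfonyl chain in an imidazoline series

The source may hold more compounds than are shown below. What is called first, only, known or untested is meant among the compounds shown, and "the series" means these compounds.

Measured compounds:
compound 1, `CS(=O)(=O)c1cc(F)ccc1NCC1=NCCN1`, in an assay for binding affinity to Alpha-1D adrenergic receptor (Homo sapiens), read by radioligand binding (on this read-out higher numbers stand for weaker inhibition and lower numbers for stronger inhibition), compound 1 gives 1620 nM
compound 2, `CC(C)S(=O)(=O)c1ccccc1NCC1=NCCN1`, in this assay compound 2 gives 2820 nM
compound 3, `CSc1ccc(Cl)cc1NCC1=NCCN1`, in this assay compound 3 gives 4.68 nM

Compound 2 holds the highest of the three numbers. Its nearest neighbour is compound 1, whose number lies within the scatter of that of compound 2, while compound 3 lies far lower, beyond the scatter. Compound 4, `CCS(=O)(=O)c1ccccc1NCC1=NCCN1`, differs from compound 2 by hydrogen in place of methyl on a saturated chain carbon bound to a saturated chain carbon and a sulfonyl sulfur, read one bond further out as isopropylsulfonyl to ethylsulfonyl. Among the compounds with values here, no pair of measured compounds isolates this change, so nothing shows its size directly. The step from compound 2 to compound 4 is expected to be small, a 1.3-fold lower number from compound 2 to compound 4 (0.11 log units; within the scatter), with no movement beyond the scatter in either direction. Compound 4 is therefore estimated at 2200 nM, within a range of 800 nM to 6000 nM.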

Compound 4, inhibition constant: 2240 nM
For compound 4 the middle estimate is 1.0-fold (0.01 log units) below the measured one, within the range that was stated.
By their numbers in this assay, from the lowest: compound 3; then compounds 1, 4 and 2 (each within the scatter of the next).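

In this assay, within the data shown here, this is the first pair of compounds to differ in one place only, and it gives a direct reading of the sulfonyl chain (a 1.3-fold lower number from compound 2 to compound 4 (0.10 log units; within the scatter)). At this position, isopropylsulfonyl and ethylsulfonyl cannot be told apart, so removing this methyl leaves the number within the scatter. No measured evidence bears on the reason for this result.

Going by these compounds, whether a longer chain such as butylsulfonyl, or a phenylsulfonyl group, would also stay within the scatter remains open. Compound 3 differs from compound 4 in more than one place, so the compounds shown do not isolate what sets its number apart.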